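Swapping an ester for an amide on the pyridine

This account rests on a few compounds, and the source may have more. Where it says the series, first, only, none or still open, it means among the compounds named here.

Of the compounds shown here, three built around one shared core have so far been tested in an assay for inhibition of Fatty-acid amide hydrolase 1 (Rattus norvegicus); a lower number here means a stronger inhibitor, a higher number a weaker inhibitor. Compound 1 `NC(=O)c1cnc(C(=O)CCc2ccc(Oc3ccccc3)cc2)o1` carries a primary amide directly on the core and a phenoxy tail; in this assay compound 1 gives 6.6 nM. Compound 2 `COC(=O)c1cc(-c2cnc(C(=O)CCc3ccc(-c4ccccc4)cc3)o2)ccn1` bears a 2-(methoxycarbonyl)pyridin-4-yl group and a biphenyl tail, and in this assay compound 2 gives 1.5 nM. Compound 3 `N#Cc1cccc(-c2cnc(C(=O)CCc3ccc(COc4ccccc4)cc3)o2)n1` has a nitrile on its pyridine and a longer tail; in this assay compound 3 gives 0.56 nM. Among these three numbers compound 2 sits second highest: compound 3 lies a little below it, beyond the usual scatter, while compound 1 lies further above it, also beyond the scatter.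

The next compound, compound 4 `NC(=O)c1ccc(-c2cnc(C(=O)CCc3ccc(-c4ccccc4)cc3)o2)nc1`, keeps the biphenyl tail of compound 2 and changes only the group on the core. 5-carbamoylpyridin-2-yl in place of 2-(methoxycarbonyl)pyridin-4-yl on an aromatic carbon The ester that leaves and the amide that enters are both small groups on a pyridine ring, and the core, the tail and the hetero-atom count of the ring stay the same. Among the compounds with values here, no measured pair here shows this exact swap, so there is nothing to copy directly. Compound 1, with a primary amide directly on the core and a different tail, gives 6.6 nM and is still a strong inhibitor. The expected step of a 1.7-fold higher number from compound 2 to compound 4 (0.22 log units; within the scatter) is therefore a small one, leaning toward a slightly weaker inhibitor but possibly within the scatter. For compound 4 the estimated value in this assay is 2.5 nM, with a likely range from 0.8 nM to 8 nM.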

Compound 4, inhibition constant: 1.3 nM
The estimate for compound 4 lay 1.9-fold (0.28 log units) above the measured number; measured number inside the range.
By their numbers in this assay, from the lowest: compound 3; then compounds 4 and 2 (each within the scatter of the next); then compound 1.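

In this assay, putting 5-carbamoylpyridin-2-yl in place of 2-(methoxycarbonyl)pyridin-4-yl gives a 1.2-fold lower number from compound 2 to compound 4 (0.06 log units; within the scatter), a step within the usual scatter, so this assay does not separate the two compounds. Within the data shown here, this is the first pair here that differs in only one place, and it shows that, with the biphenyl tail held fixed, this aromatic carbon of the shared core can take either group without a change beyond the scatter, even though the entering group has a hydrogen-bond donor and the leaving group has none. Nothing measured here explains why the two groups give such similar numbers.

The swap changes the ester to a primary amide and also alters the pyridine's substitution and attachment, as the two group names show, so these compounds leave open what each of those changes would do alone. They also leave open whether the same freedom at this position extends to a pyridine carrying a carboxylic acid or an amine in place of the ester or amide.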